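Chloro-to-cyano exchange on a shared benzimidazole-type series

The source may hold more compounds than are shown below. What is called first, only, known or untested is meant among the compounds shown, and "the series" means these compounds.

Measured in an assay on V79 cells for inhibition of cytochrome P450 11B2, mitochondrial (Homo sapiens), read by HTRF, with a stated time of 1 h; a lower number here means a stronger inhibitor, a higher number a weaker inhibitor:
compound 1 `Fc1cncc(-c2nc3cc(F)c(Cl)cc3n2C2CC2)c1`, 0.8 nM
compound 2 `N#Cc1cc2c(cc1F)nc(-c1cncc(F)c1)n2C1CC1`, 1 nM
compound 3 `Clc1ccc2nc(-c3cccnc3)n(C3CC3)c2c1`, 2.2 nM

Compound 3 stands highest of the three; its nearest neighbour is compound 2, and its values against compound 1 and compound 2 lie beyond the scatter. The difference between the core of compound 3 and the core of compound 1 is not broken down here.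

From compound 1 to compound 2 the change is cyano in place of chloro on an aromatic carbon; the step is a 1.3-fold higher number from compound 1 to compound 2 (0.10 log units; within the scatter).

Compound 4 `N#Cc1ccc2nc(-c3cccnc3)n(C3CC3)c2c1` is not yet measured. From compound 3 it differs by cyano in place of chloro on an aromatic carbon. This is the same kind of change as from compound 1 to compound 2, not the same: there the place is ortho to a fluoro group, here it is not. The step is expected to be small, a 1.2-fold higher number from compound 3 to compound 4 (0.07 log units; within the scatter), because the earlier exchange gave a 1.3-fold higher number from compound 1 to compound 2 (0.10 log units; within the scatter). Compound 4 is thus estimated at 2.6 nM, with a range of 1.2 nM to 6 nM.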

Compound 4, half-maximal inhibitory concentration: 1.2 nM
For compound 4 the middle estimate is 2.2-fold (0.34 log units) above the measured one; the measured number falls inside the stated range.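

In this assay cyano in place of chloro on an aromatic carbon of the core of compound 3 gives a 1.8-fold lower number from compound 3 to compound 4 (0.26 log units; within the scatter) and so leaves the number within the usual scatter. Two pairs do not show that the exchange would behave the same way on any further core, and neither step can be told apart from no change. Across these two cores, the exchange shows no difference that can be resolved: the same change on two cores in this assay, a 1.3-fold higher number (0.10 log units; within the scatter) from compound 1 to compound 2 and a 1.8-fold lower number (0.26 log units; within the scatter) from compound 3 to compound 4, 2.3-fold (0.36 log units) apart, within the scatter of two such steps

The compounds shown leave open whether an amine, a carboxylic acid or a longer chain at the same place would hold the number as chloro and cyano do. As far as these compounds go, how the exchange reads outside this assay also stays open.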